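One fluoro added to compound 2

The compounds below may be only part of what the source reports. "The series", "measured", "known", "first", "only" and "open" are said of these compounds alone.

Compound 1 `OC[C@H]1O[C@@H](n2cnc3c(N4CCN(c5ncccn5)CC4)ncnc32)[C@H](O)[C@@H]1O` gives 40000 nM
Compound 2 `Nc1nc(N2CCN(c3ccccc3)CC2)c2ncn([C@@H]3O[C@H](CO)[C@@H](O)[C@H]3O)c2n1` gives "not active" (no number reported)

In a functional assay on MCF7 cells (Homo sapiens) for antiproliferative activity, read by sulforhodamine B assay, with a stated time of 72 h (on this read-out higher numbers stand for weaker inhibition and lower numbers for stronger inhibition), compound 2 has no single number, being reported as "not active" (no number reported) without a concentration. The structure of compound 3 is `Nc1nc(N2CCN(c3ccc(F)cc3)CC2)c2ncn([C@@H]3O[C@H](CO)[C@@H](O)[C@H]3O)c2n1` and it differs in one place. The change fluoro in place of hydrogen on an aromatic carbon puts fluoro in place of hydrogen on an aromatic carbon. Among the compounds with values here, no measured step shows how much such a change matters, so no step beyond the scatter is expected in this assay and the result may again lack a number. Within the data shown here, the only number available is that of compound 1 at 40000 nM and the estimate stays near it. For compound 3 the expected value is 35000 nM within an estimated range from 12000 nM to 90000 nM if a number is reported at all.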

Compound 3, half-maximal inhibitory concentration: "not active" (no number reported)
The entry for compound 3 holds no number; the estimate stays without a comparison.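

In this assay compound 2 and compound 3 both carry no number, so no step can be read between them. As far as these compounds go, how far phenyl to 4-fluorophenyl shifts activity stays open, and no evidence bears on this result.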